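This account rests on a few compounds, and the source may have more. Where it says the series, first, only, none or still open, it means among the compounds named here.

Within the data shown here, compound 2 `C/C(=C\c1cc(/C=C/C(=O)NO)n(C)c1)C(=O)c1ccccc1` gives 680 nM in an assay on isolated protein for inhibition of histone deacetylase HD2 (Zea mays); a higher number here means a weaker inhibitor, a lower number a stronger inhibitor; that is the higher of the two numbers known so far, but compound 1 `COc1cccc(C(=O)/C=C/c2cc(/C=C/C(=O)NO)n(C)c2)c1`, which gives 540 nM in this assay, sits within the scatter of it, so no order between the two is claimed. The shared core carries the hydroxamic acid side chain unchanged in both.

Compound 3 `CC/C(=C\c1cc(/C=C/C(=O)NO)n(C)c1)C(=O)c1ccccc1` is the next member and differs from compound 2 by methyl in place of hydrogen on a saturated chain carbon bound to a double-bonded chain carbon. Among the measured compounds shown here, no measured pair shows this change, so there is no step to read from. The change is small in size and leaves the rest of the molecule untouched, so the expectation is a step that is none beyond the scatter, or at most a modest weakening. For compound 3 the expected value in this assay is 850 nM, with a range from 350 nM to 2100 nM. That estimate means an expected step of a 1.3-fold higher number from compound 2 to compound 3 (0.10 log units; within the scatter).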

Compound 3, half-maximal inhibitory concentration: 420 nM
For compound 3 the middle estimate is 2.0-fold (0.31 log units) above the measured one; the measured number falls inside the stated range.
By their numbers in this assay, from the lowest: compounds 3, 1 and 2 (each within the scatter of the next).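

This position now has its first reading in this assay: methyl in place of hydrogen on a saturated chain carbon bound to a double-bonded chain carbon, which turns methyl to ethyl, gives a 1.6-fold lower number from compound 2 to compound 3 (0.21 log units; within the scatter). That step lies within the scatter, so the position takes this added carbon without a change that can be told from repeat measurement, and no direction can be read from it. No data bearing on the cause accompany this result.

Still open, on these data alone, is whether a longer chain such as propyl, or a chain ending in an amine or a carboxylic acid, at this same position would move the number beyond the scatter. Also open, as far as these compounds go, is whether ethyl here gives a similar reading alongside the methoxy group carried by compound 1.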